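A few compounds are considered here, and "the series" means these few. Any claim that something is new, unique, unknown or untested is made for them only; others in the source may bear on it.

Of the compounds shown here, two sharing one core have been measured so far. In a physicochemical assay for lipophilicity, read by HPLC, measured as octanol-water partition (on this read-out higher numbers stand for higher lipophilicity and lower numbers for lower lipophilicity), compound 2 `O=C(N/N=C/c1ccc2no[n+]([O-])c2c1)c1ccc([N+](=O)[O-])cc1` gives 0.9, the lower of the two numbers, while compound 1 `Nc1ccccc1C(=O)N/N=C/c1ccc2no[n+]([O-])c2c1` gives 2, a gap beyond the usual scatter. Compound 3 `Nc1ccc(C(=O)N/N=C/c2ccc3no[n+]([O-])c3c2)cc1` has not yet been measured. It differs from compound 2 at one place, with amino in place of nitro on an aromatic carbon, para to a large group: amino in place of nitro on an aromatic carbon. Going by the values given here, no measured pair differs in only one place, so the size of this step in this assay cannot be read directly from the data. Among the compounds with values here, the one measured compound carrying amino, compound 1 at 2, stands higher, so a moderate upward step is expected, though with wide uncertainty. The expected change is a number 0.50 log units higher from compound 2 to compound 3 (beyond the scatter). For compound 3, the estimated value is 1.4, within an expected range of 0.7 to 2.1.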

Compound 3, partition coefficient: 1.2
Compound 3: the middle estimate sits 0.20 log units above what was measured, within the range that was stated.
By their numbers in this assay, from the lowest: compounds 2 and 3 (each within the scatter of the next); then compound 1.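

In this assay amino in place of nitro on an aromatic carbon, para to a large group, gives a number 0.30 log units higher from compound 2 to compound 3 (within the scatter), so at this position the change does not separate the two compounds. The amino group alone therefore does not put a compound level with compound 1: 4-aminophenyl in place of 2-aminophenyl on a carbonyl carbon gives a number 0.80 log units lower from compound 1 to compound 3 (beyond the scatter), which shows that where the amino group sits on the ring matters in this assay. Nothing available bears on what lies behind either step.

Going by these compounds, whether a carboxylic acid, a methoxy group or a dimethylamino group on the same aromatic carbon would read apart from compound 2 and compound 3 remains open. Also open, on these data alone, is whether nitro in place of amino on the ring of compound 1 would give a step of similar size.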